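Exchanging Vinyl for Bromomethyl on the Ether Chain

The compounds below may be only part of what the source reports. "The series", "measured", "known", "first", "only" and "open" are said of these compounds alone.

Compound 1 `BrCCCCCOc1c(Br)cc(Br)cc1Oc1ccc(Br)cc1Br`: 29.5 ug/mL
Compound 2 `C=CCOc1c(Br)cc(Br)cc1Oc1ccc(Br)cc1Br`: 29 ug/mL

In a functional assay on U-937 cells (Homo sapiens) for cytotoxicity, read by MTT assay, with a stated time of 24 h (a higher number here means a weaker inhibitor, a lower number a stronger inhibitor), compound 1 gives 29.5 ug/mL and compound 2 gives 29 ug/mL. Compound 2 therefore stands level with compound 1, the two values lying within the scatter of each other.

Compound 3 `BrCCOc1c(Br)cc(Br)cc1Oc1ccc(Br)cc1Br` departs from compound 2 at a single place: bromomethyl in place of vinyl on a saturated chain carbon bound to an oxygen on an aromatic ring. In words, bromomethyl stands in place of vinyl on a saturated chain carbon bound to an oxygen on an aromatic ring, so that allyloxy becomes 2-bromoethoxy.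

Among the compounds with values here, the only measured step that bears on this change is a 1.0-fold lower number from compound 1 to compound 2 (0.01 log units; within the scatter), with vinyl in place of 4-bromobutyl at that same place, and it stays within the scatter. Within the data shown here, no measured step exchanges these two groups directly, and two compounds are a thin basis. Even so, a step beyond the scatter is not expected in this assay. The expected step is a 1.0-fold lower number from compound 2 to compound 3 (0.02 log units; within the scatter). For compound 3 the estimated value is 28 ug/mL, with an expected range of 16 ug/mL to 48 ug/mL.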

Compound 3, half-maximal inhibitory concentration: 32.5 ug/mL
Compound 3: middle estimate off by 1.2-fold (0.06 log units), on the low side; low and high end bracket the measured number.
By their numbers in this assay, from the lowest: compounds 2, 1 and 3 (each within the scatter of the next).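

In this assay the exchange of vinyl for bromomethyl is a small one, with a 1.1-fold higher number from compound 2 to compound 3 (0.05 log units; within the scatter) and, for bromo in place of 3-bromopropyl, a 1.1-fold higher number from compound 1 to compound 3 (0.04 log units; within the scatter) as the companion step, and both stay within the scatter. Compounds 1, 2 and 3 therefore stand level at this place, so that neither the loss of the double bond outside aromatic rings in going from allyl to 2-bromoethyl nor the change of the bromoalkyl chain from compound 1 to compound 3 separates them in this assay, and a third group on the ether chain now reads the same as the first two. Nothing measured here gives a reason for this flat reading.

As far as these compounds go, these three groups are all small neutral ends without hydrogen-bond donors, and whether an amine, a hydroxyl or a carboxylic acid at the end of the ether chain would give a step beyond the scatter remains open. From the compounds shown here alone, it is equally open whether the level reading would hold for a chain with no bromine and no double bond, such as a plain propyl or butyl group.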